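One stereocentre drawn as R

The source may hold more compounds than are shown below. What is called first, only, known or untested is meant among the compounds shown, and "the series" means these compounds.

Of the compounds shown here, two carry numbers so far in an ADME assay on MT4 cells (Homo sapiens) for cytotoxicity, read by MTT assay, with a stated time of 5 days (a higher number here means that more compound is tolerated, a lower number that less compound is tolerated), and set the frame. There compound 1 `N#Cc1ccc(Nc2nccc([C@H](O)c3ccc(-c4ccc(C#N)cc4)cc3F)n2)cc1` gives 30000 nM as its half-maximal cytotoxic concentration. Compound 2 `Cc1cc(-c2ccc(C#N)cc2)ccc1C(O)c1ccnc(Nc2ccc(C#N)cc2)n1` gives 9940 nM on the same read-out and stands as the lower of the two numbers, with the gap to compound 1 beyond the scatter.

The next entry is compound 3 `Cc1cc(-c2ccc(C#N)cc2)ccc1[C@@H](O)c1ccnc(Nc2ccc(C#N)cc2)n1`, which keeps the same atoms and bonds as compound 2. The change is the two compounds have the same atoms and bonds; at least one stereo element is drawn with a configuration in one of them and without one in the other: 1 of 1 stereo elements differ; a stereocentre at a saturated chain carbon is drawn without a configuration in compound 2 and R in compound 3 and nothing else. Among the measured compounds shown here, no measured pair shows a step at a single place, so the size of this step rests on the structural change alone. No shift beyond the scatter is expected in this assay in either direction. The expected size is a 1.1-fold higher number from compound 2 to compound 3 (0.04 log units; within the scatter) and lies within the scatter. The estimate is anchored on compound 2 at 9940 nM and is kept slightly wider upward, where compound 1 reaches 30000 nM on this read-out. For compound 3 the estimated value is 11000 nM with an expected range from 5000 nM to 24000 nM on this read-out.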

Compound 3, half-maximal cytotoxic concentration: 35600 nM
The estimate for compound 3 lay 3.2-fold (0.51 log units) below the measured number, outside the stated range (above it).
By their numbers in this assay, from the lowest: compound 2; then compounds 1 and 3 (each within the scatter of the next).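

Without any change in atoms or bonds, this assay still separates this pair, with a 3.6-fold higher number from compound 2 to compound 3 (0.55 log units; beyond the scatter). So the saturated chain carbon bearing the stereocentre matters to this read-out in a way the earlier compounds could not show, and the only structural feature the step can be tied to is this: the fact that one of compounds 2 and 3 is drawn with a defined configuration and the other without, at the place where they differ. Among the compounds shown here, the swap of methyl in place of fluoro on an aromatic carbon gives a 1.2-fold higher number from compound 1 to compound 3 (0.07 log units; within the scatter), so within these compounds that swap does not separate the read-out, and compound 2, the one compound with no drawn configuration, stands apart from both compound 1 and compound 3.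

The compounds shown leave open how the S configuration at this carbon reads in this assay, and what the undefined drawing of compound 2 represents in terms of its make-up. They also leave open how the read-out responds when an amine or a methoxy group stands in place of the hydroxyl on this carbon.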